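The source may hold more compounds than are shown below. What is called first, only, known or untested is meant among the compounds shown, and "the series" means these compounds.

Compound 1 `COC(=O)c1cc(-c2cccc(NC(=O)c3ccc(/C=C/C(=O)c4cc(OC)c(OC)c(OC)c4)cc3)c2)on1` sits, in an ADME assay on Vero cells (Chlorocebus sabaeus) for cytotoxicity, read by MTT assay, with a stated time of 72 h (a lower number here means that less compound is tolerated, a higher number that more compound is tolerated), only at a limit rather than at a number: compound 1 gives > 50 ug/mL, a limit of the assay. Compound 2 `COC(=O)c1cc(-c2cccc(NC(=O)c3ccc(/C=C/C(=O)c4ccccc4OC)cc3)c2)on1` also reaches only a limit in this assay, giving > 40 ug/mL. Compound 3 `COC(=O)c1cc(-c2cccc(NC(=O)c3ccc(/C=C/C(=O)c4ccccc4Br)cc3)c2)on1`, too, stops at a limit in this assay, with > 40 ug/mL. The steps among these three, a step that the two limits leave unreadable from compound 1 to compound 2, a step that the two limits leave unreadable from compound 1 to compound 3 and a step that the two limits leave unreadable from compound 2 to compound 3, are therefore unreadable, as the two limits show: the limit of > 40 ug/mL in this assay, at which 2 of the 3 values shown sit, and (the limit of > 50 ug/mL in this assay, at which 1 of the 3 values shown sits). Compound 4 `COC(=O)c1cc(-c2cccc(NC(=O)c3ccc(/C=C/C(=O)c4ccc(OC)c(OC)c4)cc3)c2)on1` differs from compound 1 in one place: hydrogen in place of methoxy on an aromatic carbon. Cut one bond further out, the change reads 3,4,5-trimethoxyphenyl to 3,4-dimethoxyphenyl. Within the data shown here, none of the measured steps bears on this change with a readable size, and the values of compounds 1, 2 and 3 all sit at limits in this assay. The expectation for compound 4 is thus that this assay will again report a limit, and any step that the limit leaves unreadable from compound 1 to compound 4 is expected to be unreadable. Compound 4 is estimated at 80 ug/mL, with a range from 40 ug/mL to 200 ug/mL.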

Compound 4, half-maximal cytotoxic concentration: > 50 ug/mL
Compound 4 gave a limit, no number; the forecaster's own chance of this, stated with the estimate: 80%; the middle value is on the limit's open side.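

Compound 4 also stops at a limit in this assay, so none of its steps to compound 1, compound 2 or compound 3 can be read: the limit of > 50 ug/mL in this assay, at which 2 of the 4 values shown sit.

The compounds shown leave open whether replacing 3,4,5-trimethoxyphenyl with 3,4-dimethoxyphenyl changes the tolerated concentration in this assay at all.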